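The source may report more compounds than this note shows. Statements on the series, on what has been measured and on what is new or still open speak of the compounds shown alone.

Of the compounds shown here, three sharing one core have so far been measured in a functional assay on the whole organism (Tail) with Rattus norvegicus as the target, in the tail flick test, with a stated time of 60 min, at a dose of 25 mg/kg by the oral route; a lower number here means less inhibition, a higher number more inhibition at the dose given (going by the name of the read-out). Compound 1 `CC(=O)N1N=C(c2ccc(F)cc2)CC1c1cn(-c2ccccc2)nc1-c1ccc(Cl)cc1` gives 44% in this assay. Compound 2 `CC(=O)N1N=C(c2ccc(F)cc2)CC1c1cn(-c2ccccc2)nc1-c1ccc(Br)cc1` gives 71%, and compound 3 `CC(=O)N1N=C(c2ccc(F)cc2)CC1c1cn(-c2ccccc2)nc1-c1ccc(C)cc1` gives 110%, the highest of the three, with both steps to it beyond the scatter: a number 66 percentage points higher from compound 1 to compound 3 (beyond the scatter) and a number 39 percentage points higher from compound 2 to compound 3 (beyond the scatter). The remaining step, a number 27 percentage points higher from compound 1 to compound 2 (beyond the scatter), also lies beyond the scatter. All three steps exchange only the group on the same aromatic carbon, and each moved the read-out by a modest to large amount. Compound 4 `COc1ccc(-c2nn(-c3ccccc3)cc2C2CC(c3ccc(F)cc3)=NN2C(C)=O)cc1` carries a further change at that same place: methoxy in place of methyl on an aromatic carbon. Within the data shown here, no measured step exchanges methyl for methoxy, so the direction of this step cannot be read from the three measured ones; they show only that a single change here tends to move the read-out well beyond the scatter. Because compound 3 already stands at 110%, the expectation for compound 4 leans somewhat lower, estimated at 85% with a range of 50% to 115%. For compound 4 this estimate means an expected step of a number 25 percentage points lower from compound 3 to compound 4 (beyond the scatter).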

Compound 4, a percentage reported as inhibition, in the whole organism at one dose (the size of the read-out at that dose, not a potency): 66%
Compound 4: middle estimate off by 19 percentage points, on the high side; measured number inside the range.
By their numbers in this assay, from the lowest: compound 1; then compounds 4 and 2 (each within the scatter of the next); then compound 3.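

Placing methoxy where methyl stood gives a number 44 percentage points lower from compound 3 to compound 4 (beyond the scatter) in this assay, so compound 3 remains the only one of the four standing clear above all the others, and a second group containing one more heavy atom does not keep its high number. The methoxy and bromo compounds cannot be told apart, with a number 5 percentage points lower from compound 2 to compound 4 (within the scatter) and methoxy still stands clear of chloro, with a number 22 percentage points higher from compound 1 to compound 4 (beyond the scatter) so the groups tried here do not all give different results. Nothing available explains why methyl stands apart from the other three groups on this aromatic carbon.

Still open, from the compounds shown here alone, is whether a longer chain such as ethyl would match methyl, and whether an amine here would fall nearer methoxy or methyl. Going by these compounds, how the four compounds would rank at other doses also remains open.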